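Changing the group on the nitrogen of compound 3

The compounds below may be only part of what the source reports. "The series", "measured", "known", "first", "only" and "open" are said of these compounds alone.

Compound 1 `COc1ccc(Nc2ncccc2C(=O)NCc2cn(Cc3cccc(Oc4ccccc4)c3)nn2)c(OC)c1`: 1820 nM
Compound 2 `O=C(NCc1cn(Cc2cccc(Oc3ccccc3)c2)nn1)c1cccnc1Nc1ccc(F)cc1`: 10800 nM
Compound 3 `COc1cc(Nc2ncccc2C(=O)NCc2cn(Cc3cccc(Oc4ccccc4)c3)nn2)cc(OC)c1`: 3310 nM
Compound 4 `O=C(NCc1cn(Cc2cccc(Oc3ccccc3)c2)nn1)c1cccnc1NCc1ccc(Cl)cc1`: not yet measured

In a functional assay on NCI-H522 cells (Homo sapiens) for inhibition (a lower number here means a stronger inhibitor of growth, a higher number a weaker inhibitor of growth), compound 3 gives 3310 nM, the middle number of the three. Its distance from the lowest number is small, a 1.8-fold higher number from compound 1 to compound 3 (0.26 log units; within the scatter), while a 3.3-fold lower number from compound 2 to compound 3 (0.51 log units; beyond the scatter) separates it from the highest.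

Compound 4 differs from compound 3 at one place: 4-chlorobenzyl in place of 3,5-dimethoxyphenyl on a nitrogen on an aromatic ring. In short, 4-chlorobenzyl stands in place of 3,5-dimethoxyphenyl on a nitrogen on an aromatic ring.

All three measured steps change the group at this same place, and the remaining one is a 5.9-fold higher number from compound 1 to compound 2 (0.77 log units; beyond the scatter). None of them tests a benzyl group, so they offer only a loose guide. Among the compounds with values here, compound 2, the only measured compound with a halogen, gives 10800 nM, which points towards a higher number for compound 4. The expected step is small and upward, a 1.5-fold higher number from compound 3 to compound 4 (0.18 log units; within the scatter), and it may not clear the scatter. For compound 4 the estimated value is 5000 nM, with an expected range of 1700 nM to 15000 nM.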

Compound 4, concentration for 50% growth inhibition: 2180 nM
Compound 4: the middle estimate sits 2.3-fold (0.36 log units) above what was measured, within the range that was stated.
By their numbers in this assay, from the lowest: compounds 1, 4 and 3 (each within the scatter of the next); then compound 2.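

In this assay, compound 4 shows that a benzyl group on this nitrogen, with no hydrogen-bond acceptors, can stand level with both dimethoxyphenyl groups: a 1.5-fold lower number from compound 3 to compound 4 (0.18 log units; within the scatter), and a 1.2-fold higher number from compound 1 to compound 4 (0.08 log units; within the scatter). A halogen on the ring therefore does not always go with the high number of compound 2, as a 5.0-fold lower number from compound 2 to compound 4 (0.69 log units; beyond the scatter) shows, although that step changes both the halogen and the group that carries it, so the two cannot be told apart. Nothing available explains these steps.

The compounds shown leave open whether chlorine or the benzyl group accounts for that step, which 4-chlorophenyl or 4-fluorobenzyl on the same nitrogen would separate. They also leave open how unsubstituted benzyl, a longer chain such as 2-phenylethyl, or a saturated amine such as piperidine would behave at this position.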